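A Fluoro Step on an Unreadable Solubility Floor

A few compounds are considered here, and "the series" means these few. Any claim that something is new, unique, unknown or untested is made for them only; others in the source may bear on it.

Compound 2 `Fc1ccc(-c2nc3cnc(Nc4ccccn4)cc3[nH]2)cc1F` has been measured in a physicochemical assay for solubility, using the shake flask method, in phosphate buffer, measured as kinetic solubility, with a stated time of 20 h, at pH 6.5 (on this read-out lower numbers stand for lower solubility and higher numbers for higher solubility), and gives < 5000 nM, which is a limit of the assay rather than a number. Compound 1 `Fc1ccc(-c2nc3cnc(Nc4ccccn4)cc3[nH]2)cc1C(F)(F)F` gives < 5000 nM in this assay, again a limit. Compound 3 `Fc1ccc(-c2nc3cnc(Nc4ccc(C(F)(F)F)cn4)cc3[nH]2)cc1F` gives < 5000 nM in this assay, also a limit. In sum, (the limit of < 5000 nM in this assay, at which 3 of the 3 values shown sit). The step that the two limits leave unreadable from compound 1 to compound 2 and the step that the two limits leave unreadable from compound 2 to compound 3 are consequently of unknown size, so neither offers a readable trend. Compound 4 `Fc1ccnc(Nc2cc3[nH]c(-c4ccc(F)c(F)c4)nc3cn2)c1` differs from compound 2 by fluoro in place of hydrogen on an aromatic carbon. The two measured steps are the only ones that bear on this change, and both are hidden by the limit, so no direction beyond the scatter can be inferred from them. Compound 4 is therefore expected to sit close to the same floor, with the step that the limit leaves unreadable from compound 2 to compound 4 estimated as small. The estimate for compound 4 in this assay is 2000 nM, with a range from 400 nM to 6000 nM.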

Compound 4, solubility: < 5000 nM
Compound 4: only a limit was reported; the forecaster's own chance of this, stated with the estimate: 85%; the middle value does not contradict the limit.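

In this assay compound 4 gives < 5000 nM, a limit of the assay, so no step can be read between compound 2 and compound 4. The compounds shown leave open how soluble any of them actually is, and whether the fluoro changes solubility at all.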